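Phenyl to cyclopropylmethyl on the ether of compound 3

The compounds below may be only part of what the source reports. "The series", "measured", "known", "first", "only" and "open" are said of these compounds alone.

Of the compounds shown here, three sharing a nitro-bearing bicyclic core have been measured in an in vitro ADME assay on the whole organism (microsomes, liver, Mus musculus) for metabolic stability, read by LC-MS, with a stated time of 24 h, at a dose of 5 mg/kg by the intravenous route; a lower number here means that the compound disappears faster, a higher number that the compound lasts longer. Compound 1 `O=[N+]([O-])c1cn2c(n1)OC[C@@H](NCc1ccc(OC(F)(F)F)c(F)c1)C2` gives 0.393 h, compound 2 `CN(Cc1ccc(OC(F)(F)F)cc1)[C@@H]1COc2nc([N+](=O)[O-])cn2C1` gives 0.183 h, and compound 3 `O=[N+]([O-])c1cn2c(n1)OC[C@@H](NCc1ccc(OC(F)(F)F)cc1Oc1ccccc1)C2` gives 0.107 h. Compound 3 holds the lowest of the three numbers; its gap to compound 2 lies within the scatter, while compound 1 stands beyond the scatter above it. Compound 4 `O=[N+]([O-])c1cn2c(n1)OC[C@@H](NCc1ccc(OC(F)(F)F)cc1OCC1CC1)C2` differs from compound 3 in one place: cyclopropylmethyl in place of phenyl on an oxygen on an aromatic ring. For the measured compounds named here, no measured pair shows this change, so the step from compound 3 to compound 4 in this assay is estimated as a 1.4-fold higher number from compound 3 to compound 4 (0.15 log units; within the scatter), with no direction expected beyond the scatter. Compound 4 is therefore expected to give 0.15 h, in a range from 0.06 h to 0.4 h.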

Compound 4, half-life: 0.0267 h
Compound 4: middle estimate off by 5.6-fold (0.75 log units), on the high side, and the stated range ends above it.
By their numbers in this assay, from the lowest: compound 4; then compounds 3 and 2 (each within the scatter of the next); then compound 1.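

In this assay, for the compounds shown here, the group on this oxygen matters: cyclopropylmethyl in place of phenyl gives a 4.0-fold lower number from compound 3 to compound 4 (0.60 log units; beyond the scatter) and so moves the number beyond the scatter, which no earlier compound could show for this position. The direction is downward, with the aromatic ring of carbon leaving and the three-membered ring entering. Nothing at hand accounts for this step. The compounds shown leave open whether a longer chain, a plain methyl or a pyridine ring on the same oxygen would stand nearer compound 3 or compound 4. One pair also cannot separate the loss of phenyl from the arrival of cyclopropylmethyl.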